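The source may hold more compounds than are shown below. What is called first, only, known or untested is meant among the compounds shown, and "the series" means these compounds.

Compound 1 `COc1nc2ccc(Br)cc2cc1C(c1ccccc1)n1cc(-c2ccccc2)nn1`: 8.25%
Compound 2 `COc1nc2ccc(Br)cc2cc1C(c1ccccc1)n1cc(CCO)nn1`: 4.54%

In an ADME assay on HEK293 cells (Homo sapiens) for cytotoxicity, read by sulforhodamine B assay, with a stated time of 48 h, tested at 10 uM (a higher number here means more inhibition at the concentration tested (going by the name of the read-out), a lower number less inhibition), compound 1 and compound 2 are not separated beyond the scatter, the step being a number 3.7 percentage points lower from compound 1 to compound 2 (within the scatter) with 2-hydroxyethyl in place of phenyl on an aromatic carbon. Compound 3 `COc1nc2ccc(Br)cc2cc1C(c1ccccc1)n1cc(-c2cccc(F)c2)nn1` differs from compound 1 by fluoro in place of hydrogen on an aromatic carbon. Among the measured compounds shown here, no measured step touches a fluoro substitution; the one step known, which exchanged the whole phenyl, stayed within the scatter, so the step of a number 0.8 percentage points higher from compound 1 to compound 3 (within the scatter) is expected to be no larger than the scatter. Compound 3 is therefore estimated at 9%, in the range -2% to 20%.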

Compound 3, a percentage reported as inhibition, at one concentration (the size of the read-out at that concentration, not a potency): 6.84%
Compound 3: middle estimate off by 2.2 percentage points, on the high side, and the stated range covers the measured number.
By their numbers in this assay, from the lowest: compounds 2, 3 and 1 (each within the scatter of the next).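

In this assay, fluoro on an aromatic carbon, meta to a large group, gives a number 1.4 percentage points lower from compound 1 to compound 3 (within the scatter) and so a small change on this phenyl ring joins the larger exchange in staying unresolved. Against the 2-hydroxyethyl compound, 3-fluorophenyl gives a number 2.3 percentage points higher from compound 2 to compound 3 (within the scatter) and the three groups at this position are thus not separated from one another. Nothing at hand explains why the numbers stay together.

Going by these compounds, whether an amine or a carboxylic acid on this phenyl ring, or a longer chain in place of 2-hydroxyethyl, would exceed the scatter stays open. Changes elsewhere on the shared core also remain open.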